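From Fluoro to Methoxy on the Lowest Compound

The source may report more compounds than this note shows. Statements on the series, on what has been measured and on what is new or still open speak of the compounds shown alone.

In an ADME assay on MRC5 cells (Homo sapiens) for inhibition, with a stated time of 72 h (on this read-out lower numbers stand for an effect already at smaller amounts and higher numbers for an effect only at larger amounts of compound), compound 1 `CO[C@H]1CC[C@H](NC(=O)c2n[nH]cc2NC(=O)c2cc(Cl)cc(Cl)c2)CC1` gives 13000 nM and compound 2 `CO[C@H]1CC[C@H](NC(=O)c2n[nH]cc2NC(=O)c2ccc(F)cc2F)CC1` gives 11000 nM. The change there is a 1.2-fold lower number from compound 1 to compound 2 (0.07 log units; within the scatter). Compound 3 `CO[C@H]1CC[C@H](NC(=O)c2n[nH]cc2NC(=O)c2ccccc2F)CC1` stands lowest of the three at 1000 nM. Compound 4 `COc1ccccc1C(=O)Nc1c[nH]nc1C(=O)N[C@H]1CC[C@H](OC)CC1` has methoxy in place of fluoro on an aromatic carbon, ortho to a large group: methoxy in place of fluoro on an aromatic carbon. Going by the values given here, two measured steps concern the same ring: a 13-fold lower number from compound 1 to compound 3 (1.11 log units; beyond the scatter) and an 11-fold lower number from compound 2 to compound 3 (1.04 log units; beyond the scatter). Both are large, so sizeable moves are possible here, but neither involves methoxy. With compound 3 already lowest at 1000 nM, a moderate rise seems likelier than a further fall. The expected change is a 2.5-fold higher number from compound 3 to compound 4 (0.40 log units; beyond the scatter). For compound 4 the estimated value is 2500 nM, with an expected range from 600 nM to 12000 nM.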

Compound 4, half-maximal effective concentration: 1500 nM
For compound 4 the middle estimate is 1.7-fold (0.22 log units) above the measured one, and the stated range covers the measured number.
By their numbers in this assay, from the lowest: compounds 3 and 4 (each within the scatter of the next); then compounds 2 and 1 (each within the scatter of the next).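

On the aromatic carbon ortho to a large group, methoxy and fluoro give readings that cannot be told apart, with a 1.5-fold higher number from compound 3 to compound 4 (0.18 log units; within the scatter). The 2-methoxyphenyl ring also keeps the number well down relative to the more substituted rings, with a 7.3-fold lower number from compound 2 to compound 4 (0.87 log units; beyond the scatter) and an 8.7-fold lower number from compound 1 to compound 4 (0.94 log units; beyond the scatter), so the low readings seen with 2-fluorophenyl are not unique to fluoro. No measurement here explains why these two groups read alike. As far as these compounds go, it remains open whether an amine or a longer chain such as ethoxy at this place would fit the same picture.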